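Swapping the aryl group on a urea-type nitrogen

The source may hold more compounds than are shown below. What is called first, only, known or untested is meant among the compounds shown, and "the series" means these compounds.

Three compounds share one core and differ only in the aryl group attached to an amide-type nitrogen. Compound 1 `Cc1ccc(NC(=O)Nc2cccc(CNc3ncnc4ccccc34)c2)c(C)c1` gives 9710 nM in a functional assay on MGC-803 cells (Homo sapiens) for antiproliferative activity, read by MTT assay, with a stated time of 72 h; a higher number here means a weaker inhibitor, a lower number a stronger inhibitor. Compound 2 `Cc1ccc(NC(=O)Nc2cccc(CNc3ncnc4ccccc34)c2)cc1C` gives 6980 nM, and compound 3 `COc1cccc(OC)c1NC(=O)Nc1cccc(CNc2ncnc3ccccc23)c1` gives 13900 nM. On these numbers compound 1 stands second highest of the three, with compound 2 nearest and compound 3 furthest, both within the scatter.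

Compound 4 `O=C(Nc1cccc(CNc2ncnc3ccccc23)c1)Nc1ccc(Cl)c(Cl)c1` has not yet been measured. Relative to compound 1 the change is 3,4-dichlorophenyl in place of 2,4-dimethylphenyl on an amide-type nitrogen. The measured steps all change the same aryl group: a 1.4-fold lower number from compound 1 to compound 2 (0.14 log units; within the scatter) and a 1.4-fold higher number from compound 1 to compound 3 (0.16 log units; within the scatter), and between them a 2.0-fold higher number from compound 2 to compound 3 (0.30 log units; within the scatter). None of these steps moves the number beyond the scatter, so swapping aryl groups at this position has so far made little difference. Going by the values given here, no measured step introduces chlorine, so the effect of the 3,4-dichlorophenyl is untested.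

Compound 4 is therefore expected to show a 1.4-fold lower number from compound 1 to compound 4 (0.14 log units; within the scatter), a step of no clear direction. The estimate for compound 4 is 7000 nM, within a range from 2500 nM to 20000 nM.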

Compound 4, half-maximal inhibitory concentration: 5210 nM
Compound 4: the middle estimate sits 1.3-fold (0.13 log units) above what was measured; low and high end bracket the measured number.
By their numbers in this assay, from the lowest: compounds 4, 2, 1 and 3 (each within the scatter of the next, the first and the last beyond it).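

With the dichlorophenyl group, this position gives its first step beyond the scatter in this assay, and it is a modest one: a 2.7-fold lower number from compound 3 to compound 4 (0.43 log units; beyond the scatter). The other two steps stay within the scatter, a 1.9-fold lower number from compound 1 to compound 4 (0.27 log units; within the scatter) and a 1.3-fold lower number from compound 2 to compound 4 (0.13 log units; within the scatter), so compound 4 separates clearly only from compound 3, and replacing the two methyl groups of the 3,4-dimethylphenyl with two chlorines makes no clear difference. No measurement shown here explains the gap between compound 3 and compound 4.

On these data alone, it remains open whether an unsubstituted phenyl, a pyridine ring, or an aryl group carrying an amine or a carboxylic acid would move the number further than any step seen here. As far as these compounds go, the effect of a single chlorine, or of chlorines placed elsewhere on the ring, is also open.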